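Chalcone-linked pyrazolopyrimidines: one methoxy group removed

The source may hold more compounds than are shown below. What is called first, only, known or untested is meant among the compounds shown, and "the series" means these compounds.

Measured so far:
compound 1, `COc1ccc(-c2cc(C(=O)/C=C/c3ccccc3)nc3cc(-c4ccccc4)nn23)cc1OC`, 23300 nM in a functional assay on MDA-MB-231 cells (Homo sapiens) for antiproliferative activity, read by MTT assay, with a stated time of 24 h; a higher number here means a weaker inhibitor, a lower number a stronger inhibitor
compound 2, `COc1ccc(/C=C/C(=O)c2cc(-c3ccc(OC)c(OC)c3)n3nc(-c4ccccc4)cc3n2)cc1`, 22000 nM in this assay
compound 3, `COc1ccc(C(=O)/C=C/c2cc(-c3ccc(OC)c(OC)c3)n3nc(-c4ccccc4)cc3n2)cc1`, 13900 nM in this assay

Three compounds share a fused core carrying a phenyl group and a methoxylated phenyl group, and differ in how the enone chain is attached and in the number of methoxy groups. Compound 2 and compound 3 contain the same atoms joined differently; the difference between the two cores is 2-((4-methoxyphenyl)carbonyl)ethenyl in place of (2-(4-methoxyphenyl)ethenyl)carbonyl on an aromatic carbon, and in this assay it gave a 1.6-fold lower number from compound 2 to compound 3 (0.20 log units; within the scatter). Compound 1 differs from compound 2 by hydrogen in place of methoxy on an aromatic carbon, a change that gave a 1.1-fold higher number from compound 2 to compound 1 (0.02 log units; within the scatter).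

Compound 4, `COc1ccc(C(=O)/C=C/c2cc(-c3ccc(OC)cc3)n3nc(-c4ccccc4)cc3n2)cc1`, has not yet been measured. It differs from compound 3 by hydrogen in place of methoxy on an aromatic carbon. This is the same kind of change as that from compound 2 to compound 1, but the surroundings differ: in compound 2 the leaving methoxy sits para to a large group, whereas in compound 3 it sits ortho to a methoxy group and meta to a large group. Among the compounds with values here, since the one measured example of this kind of change gave a 1.1-fold higher number from compound 2 to compound 1 (0.02 log units; within the scatter), the step of a 1.1-fold higher number from compound 3 to compound 4 (0.05 log units; within the scatter) is expected to be of similar size, resting on the single comparison between compound 2 and compound 1. Compound 4 is therefore estimated at 15500 nM, with a plausible range from 7000 nM to 34000 nM.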

Compound 4, half-maximal inhibitory concentration: 6300 nM
Beside the measured number, compound 4's estimate is 2.5-fold (0.39 log units) above it, outside the stated range (below it).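

In this assay, replacing 3,4-dimethoxyphenyl with 4-methoxyphenyl gave a 2.2-fold lower number from compound 3 to compound 4 (0.34 log units; beyond the scatter), a modest step and the only one among these compounds that clears the scatter. Set beside the one earlier example of hydrogen in place of methoxy, this step cannot be told apart from it: the same change on two cores in this assay, a 1.1-fold higher number (0.02 log units; within the scatter) from compound 2 to compound 1 and a 2.2-fold lower number (0.34 log units; beyond the scatter) from compound 3 to compound 4, 2.3-fold (0.37 log units) apart, within the scatter of two such steps. The result shows that the change can give a lower number on one core while giving no readable shift on another, but it does not show that the core sets the size of the step, and two pairs, in which the methoxy also leaves different places, give no dependable size for a further core.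

The compounds shown leave open whether the lower number of compound 4 depends on the way the enone chain is attached, as compound 4 has no partner that differs from it only in that attachment. They also leave open what happens when a group other than hydrogen takes the place of the departing methoxy, such as a hydroxy group, a fluorine atom or a dimethylamino group.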